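This account rests on a few compounds, and the source may have more. Where it says the series, first, only, none or still open, it means among the compounds named here.

Three compounds that share one core have been run through an ADME assay on microsomes from liver (Homo sapiens) for metabolic stability, tested at 2.5 uM; on this read-out lower numbers stand for slow clearance and higher numbers for fast clearance. Compound 1, `COc1cccc(-c2c(S(=O)(=O)c3ccc(OC)c(Cl)c3)cnc3cc(F)ccc23)c1`, gives 1.71 mL/min; compound 2, `COc1ccc(-c2c(S(=O)(=O)c3ccc(F)c(F)c3)cnc3cc(F)ccc23)cc1`, gives 1.1 mL/min; and compound 3, `O=S(=O)(c1ccc(F)c(Cl)c1)c1cnc2cc(F)ccc2c1-c1cccc(Cl)c1`, gives 0.66 mL/min. The smallest of the three numbers belongs to compound 3, but its gap to compound 2 lies within the scatter of repeated measurements, so these two cannot be told apart on this evidence. The gap from compound 3 to compound 1 is beyond the scatter, so compound 1 clearly shows the faster clearance.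

Compound 4, `O=S(=O)(c1ccc(F)c(Cl)c1)c1cnc2cc(F)ccc2c1-c1cccc(F)c1`, has not yet been measured in this assay. It differs from compound 3 in one place: fluoro in place of chloro on an aromatic carbon. Read one bond further out, the 3-chlorophenyl becomes a 3-fluorophenyl. Among the compounds with values here, no measured pair here shows this exchange, so there is no step to lean on. For a swap of one halogen for another in the same place, the expected step of a 1.2-fold lower number from compound 3 to compound 4 (0.08 log units; within the scatter) is small and not beyond the scatter. Compound 4 is therefore estimated at 0.55 mL/min, with a range from 0.3 mL/min to 1.1 mL/min.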

Compound 4, intrinsic clearance in a liver preparation (reported as CLH), per the amount of preparation that the assay uses: 0.25 mL/min
Beside the measured number, compound 4's estimate is 2.2-fold (0.34 log units) above it; measured number outside the range, below it.
By their numbers in this assay, from the lowest: compound 4; then compounds 3, 2 and 1 (each within the scatter of the next, the first and the last beyond it).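

This is the first change in one place among the compounds shown, and it shows that the choice of halogen here is not a minor detail: in this assay, going from 3-chlorophenyl to 3-fluorophenyl gives a 2.6-fold lower number from compound 3 to compound 4 (0.42 log units; beyond the scatter) and leaves the rest of the molecule unchanged. Compound 1, compound 2 and compound 3 differ from one another in more than one place, so they could not isolate the effect of this position. Nothing at hand explains why exchanging one halogen for another moves the number this far.

This single pair cannot show whether the same exchange gives a similar step when the rest of the molecule is different. From the compounds shown here alone, how a nitrile, an amine or a carboxylic acid at this place on the aromatic ring would compare also remains open.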